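Bromo for Phenyl on a Second Core: Metabolic Stability

The source may report more compounds than this note shows. Statements on the series, on what has been measured and on what is new or still open speak of the compounds shown alone.

Measured compounds:
compound 1, `CCCNC(=O)[C@@H]1C[C@H]2CCC[C@@H](C1)[C@@H]2NC(=O)c1cc2sc(-c3ccccc3)nc2n1Cc1ccc(OC)cc1`, 0.453 h
compound 2, `CCCNC(=O)[C@H]1[C@@H]2CCC[C@H]1CN(C(=O)c1cc3sc(-c4ccccc4)nc3n1Cc1ccc(OC)cc1)C2`, 0.585 h
compound 3, `CCCNC(=O)[C@@H]1C[C@H]2CCC[C@@H](C1)[C@@H]2NC(=O)c1cc2sc(Br)nc2n1Cc1ccc(OC)cc1`, 0.867 h

Compounds 1 and 3 share one core, compound 2 has another; the difference between the two cores is not broken down here. In an ADME assay on microsomes from liver (Homo sapiens) for metabolic stability (a higher number here means that the compound lasts longer, a lower number that the compound disappears faster), compound 1 gives 0.453 h and compound 3 gives 0.867 h; the step of a 1.9-fold higher number from compound 1 to compound 3 (0.28 log units; within the scatter) rests on the change (bromo in place of phenyl on an aromatic carbon). Compound 2 gives 0.585 h, which sits between the other two within the scatter. Compound 4, `CCCNC(=O)[C@H]1[C@@H]2CCC[C@H]1CN(C(=O)c1cc3sc(Br)nc3n1Cc1ccc(OC)cc1)C2`, not yet measured in this assay, carries the same change on the core of compound 2: bromo in place of phenyl on an aromatic carbon. Because the step of a 1.9-fold higher number from compound 1 to compound 3 (0.28 log units; within the scatter) was itself within the scatter, the step from compound 2 to compound 4 is expected to be of similar size, a 1.7-fold higher number from compound 2 to compound 4 (0.23 log units; within the scatter), and compound 4 is estimated at 1 h, between 0.55 h and 1.9 h.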

Compound 4, half-life: 0.0482 h
Compound 4: middle estimate off by 21-fold (1.32 log units), on the high side; measured number below the stated range.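

In this assay, bromo in place of phenyl on an aromatic carbon gave a 12-fold lower number from compound 2 to compound 4 (1.08 log units; beyond the scatter), a large step. Among these compounds, the same change therefore did not carry over unchanged from one core to the other: the same change on two cores in this assay, a 1.9-fold higher number (0.28 log units; within the scatter) from compound 1 to compound 3 and a 12-fold lower number (1.08 log units; beyond the scatter) from compound 2 to compound 4, 23-fold (1.37 log units) apart, beyond the scatter of two such steps This comparison rests on only two pairs, so it shows that the outcome of the change can depend on the core, but not which feature of the cores is responsible or how the change would behave on any further core.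

The compounds shown leave open whether the large step belongs to bromo itself or would also appear with chloro, methyl or a pyridyl ring on that aromatic carbon. They also leave open whether a longer chain in place of the propyl on the amide would alter the difference between the two cores.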